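Same aryl exchange tried again on a methylated core

This account rests on a few compounds, and the source may have more. Where it says the series, first, only, none or still open, it means among the compounds named here.

Measured compounds:
compound 1, `CCS[C@@H]1[C@H](SCC)[C@@H](Cn2cc(-c3ccc(OC)cc3)nn2)O[C@H]1n1ccc(=O)[nH]c1=O`: 16200 nM
compound 2, `CCS[C@@H]1[C@H](SCC)[C@@H](Cn2cc(-c3ccccc3C(F)(F)F)nn2)O[C@H]1n1ccc(=O)[nH]c1=O`: 30300 nM
compound 3, `CCS[C@@H]1[C@H](SCC)[C@@H](Cn2cc(-c3ccc(OC)cc3)nn2)O[C@H]1n1cc(C)c(=O)[nH]c1=O`: 22800 nM

Of the compounds shown here, three of one series have been tested in a functional assay on HepG2 cells (Homo sapiens) for cytotoxicity, read by MTT assay, with a stated time of 72 h; a lower number here means that less compound is needed, a higher number that more compound is needed for the effect. Compound 1 gives 16200 nM, compound 2 gives 30300 nM and compound 3 gives 22800 nM. All three numbers lie close together: a 1.9-fold higher number from compound 1 to compound 2 (0.27 log units; within the scatter), and a 1.4-fold higher number from compound 1 to compound 3 (0.15 log units; within the scatter). Compound 3 and compound 2 are likewise within the scatter of each other, so no order among the three can be drawn.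

The change from compound 1 to compound 2 is 2-(trifluoromethyl)phenyl in place of 4-methoxyphenyl on an aromatic carbon. The two cores differ by methyl in place of hydrogen on an aromatic carbon. Compound 4, `CCS[C@@H]1[C@H](SCC)[C@@H](Cn2cc(-c3ccccc3C(F)(F)F)nn2)O[C@H]1n1cc(C)c(=O)[nH]c1=O`, has not yet been measured in this assay; it differs from compound 3 by 2-(trifluoromethyl)phenyl in place of 4-methoxyphenyl on an aromatic carbon. The place of this change is described in exactly the same words as for the earlier pair, so it is the same change made on a core that carries the methyl.

Within the data shown here, the expected step for compound 4 is a 1.8-fold higher number from compound 3 to compound 4 (0.24 log units; within the scatter), set beside the measured step because a 1.9-fold higher number from compound 1 to compound 2 (0.27 log units; within the scatter) is the only direct precedent for this exchange. With that step applied to compound 3, compound 4 is expected to give 40000 nM in this assay. The range expected for compound 4 runs from 18000 nM to 90000 nM, wide enough to take in a step that falls within the scatter.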

Compound 4, half-maximal effective concentration: 22100 nM
Estimate against measurement, compound 4: 1.8-fold (0.26 log units) above; low and high end bracket the measured number.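

In this assay, the aryl exchange on the methylated core gives a 1.0-fold lower number from compound 3 to compound 4 (0.01 log units; within the scatter), and the two readings of this exchange do not differ beyond what repeated measurement allows: the same change on two cores in this assay, a 1.9-fold higher number (0.27 log units; within the scatter) from compound 1 to compound 2 and a 1.0-fold lower number (0.01 log units; within the scatter) from compound 3 to compound 4, 1.9-fold (0.29 log units) apart, within the scatter of two such steps. The methyl, read on the core that carries 2-(trifluoromethyl)phenyl, gives a 1.4-fold lower number from compound 2 to compound 4 (0.14 log units; within the scatter), and its two readings also agree within the scatter: the same change on two cores in this assay, a 1.4-fold higher number (0.15 log units; within the scatter) from compound 1 to compound 3 and a 1.4-fold lower number (0.14 log units; within the scatter) from compound 2 to compound 4, 1.9-fold (0.29 log units) apart, within the scatter of two such steps. The four compounds thus show that neither change, made on either of the two cores, gives a step that can be told from the scatter, but they do not show that either change has a real effect that carries over, since a transfer can only be tested on a step that stands clear of the scatter.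

The compounds shown leave open whether an aryl group bearing an amine or a carboxylic acid, in place of 4-methoxyphenyl or 2-(trifluoromethyl)phenyl, would move the number beyond the scatter. They also leave open whether a longer chain in place of the two ethyl groups on sulfur would do so, and whether any such step would then hold on both the methylated core and the core of compound 1.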